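A few compounds are considered here, and "the series" means these few. Any claim that something is new, unique, unknown or untested is made for them only; others in the source may bear on it.

In an assay on CHO-K1 cells for displacement of a labelled ligand from melanin-concentrating hormone receptor 1 (Homo sapiens), read by scintillation proximity assay, with a stated time of 2 h (on this read-out lower numbers stand for stronger inhibition and higher numbers for weaker inhibition), three compounds sharing one core have been measured. Compound 1 `Cc1nc(N(C)C2CCCC2)nc2ccc(NC(=O)/C=C/c3ccc(Cl)cc3)cc12` gives 399 nM, compound 3 `Cc1nc(N2CCC(O)(C3CC3)CC2)nc2ccc(NC(=O)/C=C/c3ccc(C(F)(F)F)cc3)cc12` gives 232 nM, and compound 2 `Cc1nc(N2CCC(NS(=O)(=O)N(C)C)CC2)nc2ccc(NC(=O)/C=C/c3ccc(OC(F)(F)F)cc3)cc12` gives 105 nM. Compound 2 thus shows the lowest number of the three, and its gaps to compound 3 and to compound 1 both lie beyond the usual scatter, so it stands as the most potent of the measured set. Compound 4 `COCC(=O)NC1CCN(c2nc(C)c3cc(NC(=O)/C=C/c4ccc(OC(F)(F)F)cc4)ccc3n2)CC1` has not yet been measured in this assay. It differs from compound 2 in one place: (methoxymethyl)carbonyl in place of dimethylsulfamoyl on an amine nitrogen. For the measured compounds named here, no measured pair differs in exactly this way, so the size of the step can only be estimated. Because compound 2 gives 105 nM, the step to compound 4 is expected to be small, either none beyond the scatter or a slight move towards a higher number, and is estimated as a 1.4-fold higher number from compound 2 to compound 4 (0.15 log units; within the scatter) in this assay. Compound 4 is accordingly expected to give 150 nM, with a range from 50 nM to 450 nM.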

Compound 4, half-maximal inhibitory concentration: 32 nM
Estimate against measurement, compound 4: 4.7-fold (0.67 log units) above; measured number below the stated range.
By their numbers in this assay, from the lowest: compound 4; then compound 2; then compounds 3 and 1 (each within the scatter of the next).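

In this assay the swap of dimethylsulfamoyl for (methoxymethyl)carbonyl on this amine nitrogen gives a 3.3-fold lower number from compound 2 to compound 4 (0.52 log units; beyond the scatter) and is a modest step beyond the scatter. For the compounds shown here, this is the only pair in the set that differs in one place, so it alone shows that the group on this nitrogen can move the number by itself, and that a carbonyl-linked group can serve there in place of a sulfamoyl one. Nothing measured here accounts for the step, which rests on this single pair.

On these data alone, whether an acetyl group, a longer ethoxyacetyl chain or the free amine on this nitrogen would move the number further remains open. The step has also been read on only one background, so whether it would hold with a chloro or trifluoromethyl group on the far aromatic ring cannot be said.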